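A Trifluoromethylphenyl Replacement Measured Against a Ceiling

The source may hold more compounds than are shown below. What is called first, only, known or untested is meant among the compounds shown, and "the series" means these compounds.

Of the compounds shown here, three sharing one core have been tested in a functional assay on HEK293 cells (Homo sapiens) for cytotoxicity; a higher number here means that more compound is tolerated, a lower number that less compound is tolerated. Compound 1 `COc1ccc([C@H]2CC(=O)N(Cc3cccc(N)c3)C2)cc1OC1CCCC1` gives only a limit there, > 10000 nM. Compound 2 `COc1ccc([C@H]2CC(=O)N(c3cccc(N)c3C)C2)cc1OC1CCCC1` likewise reaches only the limit > 10000 nM in this assay. Compound 3 `COc1ccc([C@H]2CC(=O)N(c3cccc(C#N)c3)C2)cc1OC1CCCC1` again returns the limit > 10000 nM. Because (the limit of > 10000 nM in this assay, at which 3 of the 3 values shown sit), the steps a step that the two limits leave unreadable from compound 1 to compound 2, a step that the two limits leave unreadable from compound 1 to compound 3 and a step that the two limits leave unreadable from compound 2 to compound 3 cannot be sized. Compound 4 `COc1ccc([C@H]2CC(=O)N(c3cccc(C(F)(F)F)c3)C2)cc1OC1CCCC1` differs from compound 2 by 3-(trifluoromethyl)phenyl in place of 3-amino-2-methylphenyl on an amide-type nitrogen in a ring. Within the data shown here, none of the measured steps offers a readable size, so no step beyond the scatter is expected, and three limits make a further limit the likeliest outcome. Compound 4 is therefore expected to sit at 15000 nM, between 5000 nM and 50000 nM. The expected step is a step that the limit leaves unreadable from compound 2 to compound 4, which is also expected to remain unreadable.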

Compound 4, half-maximal cytotoxic concentration: > 10000 nM
Compound 4 gave a limit, no number; the forecaster's own chance of this, stated with the estimate: 80%; the middle value is on the limit's open side.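

The steps from compound 1, compound 2 and compound 3 to compound 4 cannot be read, since all four compounds sit at one limit: the limit of > 10000 nM in this assay, at which 4 of the 4 values shown sit.

The compounds shown leave open whether the groups on the amide-type nitrogen differ at all in this assay.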